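The source may report more compounds than this note shows. Statements on the series, on what has been measured and on what is new or still open speak of the compounds shown alone.

Measured compounds:
- compound 1, `Cc1ccc(Cn2cc(COc3ccc4c(=O)ccoc4c3)nn2)cc1` — > 100000 nM
- compound 2, `O=c1ccoc2cc(OCc3cn(Cc4cccc(Br)c4)nn3)ccc12` — > 100000 nM
- compound 3, `O=c1ccoc2cc(OCc3cn(Cc4ccc(Cl)cc4Cl)nn3)ccc12` — 80600 nM

In a functional assay on HeLa cells (Homo sapiens) for cytotoxicity, read by MTT assay, with a stated time of 48 h (on this read-out lower numbers stand for stronger inhibition and higher numbers for weaker inhibition), compound 1 gives > 100000 nM, which is a limit of the assay rather than a number. Compound 2 likewise gives > 100000 nM, again a limit. For the measured compounds named here, compound 3 gives 80600 nM, the only actual number among the three, so it stands as the sole compound whose inhibition could be quantified here. The steps toward it are small: an at least 1.2-fold lower number from compound 1 to compound 3 (0.09 log units; that floor lies within the scatter), and an at least 1.2-fold lower number from compound 2 to compound 3 (0.09 log units; that floor lies within the scatter); the step that the two limits leave unreadable from compound 1 to compound 2. The reason so little can be read is the limit of > 100000 nM in this assay, at which 2 of the 3 values shown sit.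

Compound 4, `O=c1ccoc2cc(OCc3cn(Cc4cccc(F)c4)nn3)ccc12`, differs from compound 3 in one place: 3-fluorophenyl in place of 2,4-dichlorophenyl on a saturated chain carbon bound to an aromatic nitrogen. Going by the values given here, no measured step swaps a 2,4-dichlorophenyl for a 3-fluorophenyl, so the measured steps offer only an outer frame: every change of the group on this chain carbon so far has left the numbers at or just under the limit. A shift back toward the limit is therefore expected, a 1.5-fold higher number from compound 3 to compound 4 (0.17 log units; within the scatter), with a fair chance that only a limit is reported. Compound 4 is estimated at 120000 nM, within a range from 50000 nM to 300000 nM in this assay.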

Compound 4, half-maximal inhibitory concentration: 7550 nM
Compound 4: the middle estimate sits 16-fold (1.20 log units) above what was measured, outside the stated range (below it).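

Changing the group on this saturated chain carbon can matter far more than the first three compounds suggested: in this assay there is an 11-fold lower number from compound 3 to compound 4 (1.03 log units; beyond the scatter). Fluoro in place of bromo on an aromatic carbon gives an at least 13-fold lower number from compound 2 to compound 4 (1.12 log units; beyond the scatter), and the replacement of 4-methylphenyl by 3-fluorophenyl gives an at least 13-fold lower number from compound 1 to compound 4 (1.12 log units; beyond the scatter); each of these two steps starts from a limit rather than a number, so each gives only a floor for the true gap. The earlier steps were either unreadable or had floors within the scatter, and they could not reveal a change of this size because most of the values sat at the top of the measurable range: the limit of > 100000 nM in this assay, at which 2 of the 4 values shown sit.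

Whether the gain belongs to the fluoro itself or to where it sits on the ring remains open, since the compounds shown do not separate these two factors. Also open, from the compounds shown here alone, is how the number would respond to a methoxy group or an amine on this ring, or to a longer chain in place of the 3-fluorobenzyl group.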